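The source may report more compounds than this note shows. Statements on the series, on what has been measured and on what is new or still open speak of the compounds shown alone.

Compounds measured so far:

Compound 1 `CCCC(=O)N1CCC(c2cc(Cl)ccc2N)=N1`: 0.29%
Compound 2 `Nc1ccc(Cl)cc1C1=NN(C(=O)C2CC2)CC1`: 18.9%
Compound 3 `CC(=O)N1CCC(c2cc(Cl)ccc2N)=N1`: 1.03%

In an assay on isolated protein for inhibition of Nitric oxide synthase, inducible (Homo sapiens), with a stated time of 30 min, tested at 1 mM (a lower number here means less inhibition, a higher number more inhibition at the concentration tested (going by the name of the read-out)), compound 3 stands second highest of the three numbers; its nearest neighbour is compound 1, and the step of a number 0.7 percentage points higher from compound 1 to compound 3 (within the scatter) lies within the scatter, while compound 2 is the furthest, the step of a number 17.9 percentage points lower from compound 2 to compound 3 (beyond the scatter) being beyond it. The steps to compound 2, a number 18.6 percentage points higher from compound 1 to compound 2 (beyond the scatter) and a number 17.9 percentage points lower from compound 2 to compound 3 (beyond the scatter), both concern cyclopropyl on the carbonyl carbon and do not bear on an open-chain change.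

Compound 4 `CCC(=O)N1CCC(c2cc(Cl)ccc2N)=N1` is not yet measured in this assay. It differs from compound 3 by methyl in place of hydrogen on a saturated chain carbon bound to a carbonyl carbon. Among the measured compounds shown here, the one measured step at this place, a number 0.7 percentage points higher from compound 1 to compound 3 (within the scatter), exchanges hydrogen for ethyl and stays within the scatter; the present change, methyl for hydrogen, is the shorter version of the same exchange, so no step beyond the scatter is expected here.

Compound 4 is therefore expected to give about 1% in this assay, within a range of -5% to 9%, a step of a number 0 percentage points lower from compound 3 to compound 4 (within the scatter) that is expected to stay within the scatter.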

Compound 4, a percentage reported as inhibition, at one concentration (the size of the read-out at that concentration, not a potency): 13.7%
Estimate against measurement, compound 4: 12.7 percentage points below; measured number above the stated range.
By their numbers in this assay, from the lowest: compounds 1 and 3 (each within the scatter of the next); then compounds 4 and 2 (each within the scatter of the next).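

In this assay the change of methyl for hydrogen on a saturated chain carbon bound to a carbonyl carbon, acetyl to propanoyl, is not silent (a number 12.7 percentage points higher from compound 3 to compound 4 (beyond the scatter)), and removing a methyl from the far end of the longer chain gives a step of similar size (a number 13.4 percentage points higher from compound 1 to compound 4 (beyond the scatter)). The small difference between the propyl and methyl compounds therefore hid a dependence on chain length that does not run in one direction: ethyl on the carbonyl stands apart from both, while ethyl and cyclopropyl cannot be separated (a number 5.2 percentage points lower from compound 2 to compound 4 (within the scatter)). No supporting measurement bears on why this single chain length differs.

Still open, from the compounds shown here alone, is whether a branched chain such as isopropyl, or an amine on the carbonyl carbon, keeps the number seen with ethyl. All these numbers come from one concentration, so potency also remains undefined.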